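This account rests on a few compounds, and the source may have more. Where it says the series, first, only, none or still open, it means among the compounds named here.

Compound 1 `Cc1ccnc(NC(c2ccc(C(F)(F)F)cc2)c2ccc3cccnc3c2O)c1` is the only one of the three measured compounds that gives a number: in an assay for inhibition of protein disulfide-isomerase (Homo sapiens), with a stated time of 1 h (on this read-out lower numbers stand for stronger inhibition and higher numbers for weaker inhibition), compound 1 gives 26500 nM. Compound 2 `CN(C)c1cccc(C(c2ccc(F)cc2)N2CCCCC2)c1O` reaches only a limit of this assay, > 30000 nM. Compound 3 `Oc1ccc2ncccc2c1C(c1ccc(F)cc1)N1CCCCC1` likewise gives only a limit, > 30000 nM. So the picture is the limit of > 30000 nM in this assay, at which 2 of the 3 values shown sit, with compound 1 not far from it. Compound 4 `Cc1ccnc(NC(c2ccccc2)c2ccc3cccnc3c2O)c1` differs from compound 1 by hydrogen in place of trifluoromethyl on an aromatic carbon. Among the measured compounds shown here, no step between measured compounds is available to guide this change. Compound 4 is expected to stay near compound 1 or drift weaker, with an estimated step of a 1.4-fold higher number from compound 1 to compound 4 (0.16 log units; within the scatter). Compound 4 is estimated at 38000 nM, expected between 12000 nM and 120000 nM.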

Compound 4, half-maximal inhibitory concentration: < 200 nM
Compound 4: a limit, no number; the forecaster's own chance of this, stated with the estimate: 55%; middle value at least 190-fold (2.27 log units) away from the limit.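

Hydrogen in place of trifluoromethyl gives an at least 130-fold lower number from compound 1 to compound 4 (2.12 log units; beyond the scatter), so what this aromatic carbon carries, para to a large group, matters greatly on the core of compound 1. The earlier compounds shown here offered no step between them and could not show this. The value of compound 4 is a limit and not a number, so the step gives only a bound: the limit of < 200 nM in this assay, at which 1 of the 4 values shown sits.

As far as these compounds go, whether any group at this place weakens inhibition, or trifluoromethyl in particular, stays open. A chlorine, a methoxy group or an amine on the same carbon would help to separate the two.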